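Hydroxy groups on a prenylated chalcone in HeLa cells

The source may report more compounds than this note shows. Statements on the series, on what has been measured and on what is new or still open speak of the compounds shown alone.

Measured so far in a functional assay on HeLa cells (Homo sapiens) for cytotoxicity, read by MTT assay; on this read-out lower numbers stand for stronger inhibition and higher numbers for weaker inhibition:
- Compound 1 `COc1cc(O)c(CC=C(C)C)c(O)c1C(=O)/C=C/c1cc(O)c(O)c(O)c1`: 30300 nM
- Compound 2 `COc1cc(O)c(CC=C(C)C)c(O)c1C(=O)/C=C/c1ccc(O)c(O)c1`: 2500 nM
- Compound 3 `COc1cc(O)cc(O)c1C(=O)/C=C/c1ccc(O)c(O)c1`: 14800 nM

Of these three, compound 2 has the lowest number at 2500 nM, and its gaps to both other compounds lie beyond the scatter. The next compound to be tested is compound 4 `COc1cc(O)c(CC=C(C)C)c(O)c1C(=O)/C=C/c1ccccc1O`, which places 2-hydroxyphenyl where compound 2 has 3,4-dihydroxyphenyl, on a double-bonded chain carbon bound to a double-bonded chain carbon: 2-hydroxyphenyl in place of 3,4-dihydroxyphenyl on a double-bonded chain carbon bound to a double-bonded chain carbon.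

Two measured steps offer some guidance. The more relevant is a 12-fold lower number from compound 1 to compound 2 (1.08 log units; beyond the scatter), a large step that also removes a hydroxy group from this same aromatic group. For the measured compounds named here, it is only one example, however, and no measured compound carries 2-hydroxyphenyl, so it cannot fix the direction here. The other step, a 5.9-fold higher number from compound 2 to compound 3 (0.77 log units; beyond the scatter), is modest and involves the 3-methylbut-2-en-1-yl group, which compound 4 keeps, so it bears on this change only loosely.

With so little to go on, no clear shift beyond the scatter is expected in this assay, with only a slight lean towards a higher number. The expected change is a 1.6-fold higher number from compound 2 to compound 4 (0.20 log units; within the scatter). For compound 4 the estimated value is 4000 nM, with an expected range from 1200 nM to 14000 nM.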

Compound 4, half-maximal inhibitory concentration: 5900 nM
The estimate for compound 4 lay 1.5-fold (0.17 log units) below the measured number; low and high end bracket the measured number.
By their numbers in this assay, from the lowest: compound 2; then compound 4; then compound 3; then compound 1.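

In this assay, the new result shows that the aromatic group on this double-bonded chain carbon does not follow a simple rule of fewer hydroxy groups giving a lower number. Replacing 3,4-dihydroxyphenyl with 2-hydroxyphenyl produces a 2.4-fold higher number from compound 2 to compound 4 (0.37 log units; beyond the scatter), so this change goes against the direction of the earlier step that removed a hydroxy group from compound 1 to reach compound 2. Yet 2-hydroxyphenyl still compares well with 3,4,5-trihydroxyphenyl, giving a 5.1-fold lower number from compound 1 to compound 4 (0.71 log units; beyond the scatter), which places the 3,4-dihydroxyphenyl compound lowest among these three and shows that this position responds to the pattern of hydroxy groups, though nothing available explains these shifts.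

In compound 4, the number of hydroxy groups and their placing change together, so the compounds shown cannot tell which of the two matters more. A 4-hydroxyphenyl group, a plain phenyl group, or a 3,4-dimethoxyphenyl group at this position would help pull those two effects apart, and an amine in place of a hydroxy group would test whether a hydroxy group is needed here at all.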